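Amide to Ketone on the Aromatic Ring

A few compounds are considered here, and "the series" means these few. Any claim that something is new, unique, unknown or untested is made for them only; others in the source may bear on it.

Among the measured compounds shown here, compound 1 `CC(=O)N[C@@H](C)C(=O)N(C)/N=N/c1ccc(C(N)=O)cc1` is one of two compounds measured in a physicochemical assay for lipophilicity, read by HPLC, in phosphate buffer, measured as octanol-water partition, at pH 7.4 (on this read-out lower numbers stand for lower lipophilicity and higher numbers for higher lipophilicity), where compound 1 gives 0.69. Compound 2 `CCCC(=O)N[C@@H](C)C(=O)N(C)/N=N/c1ccc(C#N)cc1` stands higher in this assay, giving 2.28, a gap beyond the usual scatter; compound 1 therefore holds the lower of the two values. Compound 3 `CC(=O)N[C@@H](C)C(=O)N(C)/N=N/c1ccc(C(C)=O)cc1` has not been measured. It differs from compound 1 by methyl in place of amino on a carbonyl carbon. For the measured compounds named here, no measured pair shows this change, so the step from compound 1 to compound 3 is expected to be upward and beyond the scatter, estimated at a number 0.91 log units higher from compound 1 to compound 3 (beyond the scatter). Compound 3 is thus expected to give about 1.6, within a range from 1.1 to 2.1.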

Compound 3, partition coefficient: 1.51
Estimate against measurement, compound 3: 0.09 log units above; measured number inside the range.
By their numbers in this assay, from the lowest: compound 1; then compound 3; then compound 2.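

Among the compounds shown here, compound 1 and compound 3 are the first pair here that differ in one place only, since compound 2 differs from compound 1 in two, so this change can now be read alone. In this assay, carbamoyl to acetyl, on a carbonyl carbon whose other neighbour is an aromatic carbon, gives a number 0.82 log units higher from compound 1 to compound 3 (beyond the scatter) for this single pair. Nothing available says why the number moves. 

Still open, from the compounds shown here alone, is where a carboxylic acid or an amine would stand in this place. Going by these compounds, a longer chain in place of the methyl on this carbonyl carbon is equally open.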